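From 4-methylpiperazin-1-yl to pyrrolidin-1-yl at the assay limit

A few compounds are considered here, and "the series" means these few. Any claim that something is new, unique, unknown or untested is made for them only; others in the source may bear on it.

Measured in a functional assay on HCT-116 cells (Homo sapiens) for antiproliferative activity, with a stated time of 48 h; on this read-out higher numbers stand for weaker inhibition and lower numbers for stronger inhibition:
compound 1 `CCN(CC)c1ccc(-c2cccc(C(F)(F)F)c2)nn1`: > 25000 nM
compound 2 `CCN(CC)c1ccc(-c2ccc(C(=O)O)cc2)nn1`: > 25000 nM
compound 3 `CN1CCN(c2ccc(-c3cccc(C(F)(F)F)c3)nn2)CC1`: > 25000 nM

Compound 3 stands at > 25000 nM, and this is a limit of the assay, not a number. The values of compound 1 and compound 2 are limits too, so the record so far is the limit of > 25000 nM in this assay, at which 3 of the 3 values shown sit. Compound 4 `FC(F)(F)c1cccc(-c2ccc(N3CCCC3)nn2)c1` carries pyrrolidin-1-yl in place of 4-methylpiperazin-1-yl on an aromatic carbon. Going by the values given here, the one measured step at this kind of place is a step that the two limits leave unreadable from compound 1 to compound 3, so it offers no size to carry over. No clear change is therefore expected in this assay. The estimated step is a step that the limit leaves unreadable from compound 3 to compound 4. For compound 4 the expected value is 30000 nM, with an estimated range from 12000 nM to 60000 nM.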

Compound 4, half-maximal inhibitory concentration: > 25000 nM
Compound 4 gave a limit, no number; the forecaster's own chance of this, stated with the estimate: 80%; the middle value lies beyond the limit too.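

Compound 4 gave only a limit of the assay, not a number, so the steps to it from compound 1 and compound 3 cannot be read: the limit of > 25000 nM in this assay, at which 4 of the 4 values shown sit.

The compounds shown leave open whether any group at this place on the shared core gives a measurable value.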